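The compounds below may be only part of what the source reports. "The series", "measured", "known", "first", "only" and "open" are said of these compounds alone.

Measured so far in a physicochemical assay for lipophilicity, read by HPLC, at pH 7.5; a lower number here means a more polar compound, a higher number a more lipophilic compound:
Compound 1 `CC[C@@H](Nc1c(C#N)c(-c2ccc(-c3ccc(OC)cc3)cc2)nc2cnccc12)C(N)=O` gives 2.7
Compound 2 `CC[C@@H](Nc1c(C#N)c(-c2ccc(-c3ccccc3C)cc2)nc2cnccc12)C(N)=O` gives 3

Among the compounds with values here, compound 2 stands at 3 and so lies within the usual scatter of compound 1, the only other compound measured. The change from compound 2 to compound 3 `CC[C@@H](Nc1c(C#N)c(-c2ccc(-c3ccc(Cl)cc3)cc2)nc2cnccc12)C(N)=O`, which has not yet been measured, is 4-chlorophenyl in place of 2-methylphenyl on an aromatic carbon and amounts to 4-chlorophenyl in place of 2-methylphenyl on an aromatic carbon, para to a large group.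

Within the data shown here, one measured step bears on this change. It concerns the same aromatic carbon on the shared core. There, 2-methylphenyl in place of 4-methoxyphenyl gave a number 0.30 log units higher from compound 1 to compound 2 (within the scatter) and thus nothing beyond the scatter. Among the measured compounds shown here, no measured compound carries the 4-chlorophenyl group, so this single step is limited support. On that evidence, no step beyond the scatter is expected in this assay for the new change. The estimated step is a number 0.10 log units higher from compound 2 to compound 3 (within the scatter) and is expected to remain small. The estimated value for compound 3 is 3.1 with an expected range from 2.7 as its lower end to 3.5 as its upper end.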

Compound 3, distribution coefficient: 3.1
Compound 3: the middle estimate sits on the measured number at the digits printed, within the range that was stated.
By their numbers in this assay, from the lowest: compounds 1, 2 and 3 (each within the scatter of the next, the first and the last beyond it).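

In this assay, putting 4-chlorophenyl in place of 2-methylphenyl on this aromatic carbon, para to a large group, gave a number 0.10 log units higher from compound 2 to compound 3 (within the scatter), so this second exchange at the position also stayed small. Within the data shown here, the new compound also gives the first step at this position that passes beyond the scatter: chloro in place of methoxy gave a number 0.40 log units higher from compound 1 to compound 3 (beyond the scatter), a modest step, while compound 2 lies within the scatter of both compound 1 and compound 3, so the three compounds span only a narrow band at this carbon. Nothing measured here explains either step.

All three compounds keep the rest of the shared core unchanged, so these readings apply to this one aromatic carbon and to three closely related aryl groups alone. As far as these compounds go, what a carboxylic acid or an amine such as dimethylamino would do in place of the chloro group in this assay stays open, as does whether a pyridine ring or a longer chain at this carbon would leave the number inside the same narrow band.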